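The source may report more compounds than this note shows. Statements on the series, on what has been measured and on what is new or still open speak of the compounds shown alone.

Measured compounds in an ADME assay on Vero cells (Chlorocebus sabaeus) for cytotoxicity, read by MTT assay, with a stated time of 72 h; a lower number here means that less compound is tolerated, a higher number that more compound is tolerated:
compound 1 `O[C@@H]1Cc2ccccc2N[C@H](c2ccccc2Cl)C1` gives > 300000 nM, a limit of the assay.
compound 2 `O[C@@H]1Cc2ccccc2N[C@H](c2ccccc2F)C1` gives > 300000 nM, a limit of the assay.
compound 3 `O[C@@H]1Cc2ccccc2N[C@H](c2c(Cl)cccc2Cl)C1` gives > 300000 nM, a limit of the assay.

For the measured compounds named here, compound 3 stands at a limit in this assay, as do the two other compounds; every value so far sits at the same point (the limit of > 300000 nM in this assay, at which 3 of the 3 values shown sit). Compound 4 `O[C@@H]1Cc2ccccc2N[C@H](c2c(F)cccc2Cl)C1` differs from compound 3 by fluoro in place of chloro on an aromatic carbon.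

Going by the values given here, two measured steps bear on this change. The step that the two limits leave unreadable from compound 1 to compound 2 is the same kind of swap, fluoro in place of chloro on an aromatic carbon, and the step that the two limits leave unreadable from compound 1 to compound 3 concerns the second halogen on the same ring; neither has a readable size, since both ends rest on limits. For compound 4 the expected step of a number no higher from compound 3 to compound 4 (the limit leaves the size open) is therefore none beyond the scatter. Compound 4 is expected to give 300000 nM in this assay, with a range from 100000 nM to 1000000 nM, most probably again reported as a limit.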

Compound 4, half-maximal cytotoxic concentration: > 300000 nM
Compound 4: a limit, no number; the forecaster's own chance of this, stated with the estimate: 85%; the middle value sits exactly at the limit.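

No step between compound 4 and compound 1, compound 2 or compound 3 can be read, because all four values rest on the same limit: the limit of > 300000 nM in this assay, at which 4 of the 4 values shown sit.

The compounds shown leave open at what concentration any of them reaches half-maximal cytotoxicity, and whether the halogen swaps alter that concentration at all.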